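Furan-2-yl gives way to 4-chlorophenyl in compound 3

The source may report more compounds than this note shows. Statements on the series, on what has been measured and on what is new or still open speak of the compounds shown alone.

In a functional assay on HeLa cells (Homo sapiens) for cytotoxicity, read by ELISA, with a stated time of 4 days (on this read-out higher numbers stand for weaker inhibition and lower numbers for stronger inhibition), compound 2 (`Clc1ccc(-c2cc(-c3ccco3)nc(-c3ccc(Cl)s3)c2)o1`) reads > 50000 nM, which is a limit of the assay and not a number. Compound 1 (`Clc1ccc(-c2cc(-c3ccoc3)cc(-c3ccc(Cl)s3)n2)cc1`), which also carries a 4-chlorophenyl group, gives 16500 nM in this assay. Compound 3 (`Clc1ccc(-c2cc(-c3ccc(Cl)o3)cc(-c3ccc(Cl)s3)n2)cc1`) has 4-chlorophenyl in place of the furan-2-yl of compound 2, next to the ring nitrogen: 4-chlorophenyl in place of furan-2-yl on an aromatic carbon. Among the compounds with values here, no measured step covers this change, so the expectation rests on compound 1 at 16500 nM. The estimated at least 2.5-fold lower number from compound 2 to compound 3 (0.39 log units; beyond the scatter) in this assay points to stronger inhibition, beyond the scatter. For compound 3 the expected value is 20000 nM, within a range of 7000 nM to 50000 nM.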

Compound 3, half-maximal inhibitory concentration: 25100 nM
The estimate for compound 3 lay 1.3-fold (0.10 log units) below the measured number; the range from low to high includes it.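

In this assay, this position now has its first comparison, but an at least 1.9-fold lower number from compound 2 to compound 3 (0.29 log units; that floor lies within the scatter) gives only a floor, so it does not establish that 4-chlorophenyl in place of furan-2-yl makes a difference beyond the scatter. Compound 2 sits at a limit of the assay, not a number: the limit of > 50000 nM in this assay, at which 1 of the 3 values shown sits.

With 5-chlorofuran-2-yl in place of furan-3-yl, a 1.5-fold higher number from compound 1 to compound 3 (0.18 log units; within the scatter) shows no separable difference. The compounds shown leave open how an amine or a carboxylic acid next to the ring nitrogen would read, and how far compound 2 truly lies from compound 3.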